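A few compounds are considered here, and "the series" means these few. Any claim that something is new, unique, unknown or untested is made for them only; others in the source may bear on it.

Measured compounds in the series:
- compound 1 `O=C(/C=C/c1cn(-c2ccccc2)nc1-c1ccsc1)c1ccccc1`: 1900 nM
- compound 2 `COc1cc(OC)c(C(=O)/C=C/c2cn(-c3ccccc3)nc2-c2ccsc2)c(OC)c1`: 2700 nM
- compound 3 `COc1ccc(C(=O)/C=C/c2cn(-c3ccccc3)nc2-c2ccsc2)cc1OC`: 2800 nM

In a functional assay on MCF7 cells (Homo sapiens) for inhibition, read by sulforhodamine B assay, with a stated time of 72 h (on this read-out higher numbers stand for weaker inhibition and lower numbers for stronger inhibition), compound 1 has the lowest number of the three, but its gaps to compound 2 and to compound 3 both lie within the scatter, so no order among them is claimed. Compound 4 `COc1ccc(C(=O)/C=C/c2cn(-c3ccccc3)nc2-c2ccsc2)c(OC)c1` differs from compound 1 by 2,4-dimethoxyphenyl in place of phenyl on a carbonyl carbon. Among the measured compounds shown here, the one measured step that bears on this is a 1.5-fold higher number from compound 1 to compound 3 (0.17 log units; within the scatter), the same kind of exchange on the same carbonyl carbon, and compound 2 with its trimethoxyphenyl sits in the same region. No step beyond the scatter is therefore expected in this assay. Compound 4 is estimated at 2500 nM, range 1200 nM to 5500 nM, an expected step of a 1.3-fold higher number from compound 1 to compound 4 (0.12 log units; within the scatter).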

Compound 4, half-maximal inhibitory concentration: 9000 nM
Compound 4: the middle estimate sits 3.6-fold (0.56 log units) below what was measured; measured number outside the range, above it.
By their numbers in this assay, from the lowest: compounds 1, 2 and 3 (each within the scatter of the next); then compound 4.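

In this assay the arrangement of methoxy groups on the aromatic ring at the carbonyl carbon counts, not just their presence: 2,4-dimethoxyphenyl in place of phenyl gives a 4.7-fold higher number from compound 1 to compound 4 (0.68 log units; beyond the scatter) and 2,4-dimethoxyphenyl in place of 3,4-dimethoxyphenyl gives a 3.2-fold higher number from compound 3 to compound 4 (0.51 log units; beyond the scatter) as well. Hydrogen in place of methoxy on an aromatic carbon gives a 3.3-fold higher number from compound 2 to compound 4 (0.52 log units; beyond the scatter) so the loss appears only without the extra methoxy of compound 2. Nothing at hand explains this shift. Open, as far as these compounds go, is whether a single methoxy on this ring already shifts the number, and whether a hydroxyl or a dimethylamino group in place of methoxy behaves alike.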